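The source may report more compounds than this note shows. Statements on the series, on what has been measured and on what is new or still open speak of the compounds shown alone.

Working notes on the series, read out in a functional assay on the whole organism with Mus musculus as the target; a higher number here means that more compound is needed for the effect, a lower number that less compound is needed. Going by the values given here, compound 1 (`CCCn1c(-c2ccc(Cl)cc2)nn(C)c1=S`) gives 12.5 mg/kg, the highest number of the three measured so far and beyond the scatter from both of the others. Compound 2 (`COc1ccc(-c2nn(C)c(=S)n2C)cc1`) gives 3.3 mg/kg and compound 3 (`Cn1nc(-c2ccc(Cl)c(Cl)c2)n(C)c1=S`) gives 4.4 mg/kg, two values within the scatter of each other. Among the compounds with values here, no measured pair differs in one place only, so no direct step is available to scale from.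

The next compound is compound 4 (`CCn1c(-c2ccc(Cl)cc2)nn(C)c1=S`), where propyl becomes ethyl: hydrogen in place of methyl on a saturated chain carbon, two bonds along the chain from an aromatic nitrogen. Compound 2 at 3.3 mg/kg and compound 3 at 4.4 mg/kg carry methyl as that chain, though both also differ elsewhere, so a move toward a lower number is expected but not established. The expected step is a 1.7-fold lower number from compound 1 to compound 4 (0.22 log units; within the scatter), a modest one near the edge of the usual scatter. For compound 4 the estimated dose is 7.5 mg/kg, with an expected range from 3.5 mg/kg to 15 mg/kg.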

Compound 4, dose for half-maximal effect: 21.2 mg/kg
Estimate against measurement, compound 4: 2.8-fold (0.45 log units) below; the measured number lies above the stated range.
By their numbers in this assay, from the lowest: compounds 2 and 3 (each within the scatter of the next); then compounds 1 and 4 (each within the scatter of the next).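

Going by these compounds alone, the first one-place step, a 1.7-fold higher number from compound 1 to compound 4 (0.23 log units; within the scatter) in this assay, shows that exchanging hydrogen for methyl at this saturated chain carbon, two bonds along the chain from an aromatic nitrogen, gives no difference that can be told from the scatter. Propyl and ethyl therefore cannot be separated at this position on the core of compound 1, and the pair gives no sign of a trend with chain length. No measurement to hand speaks to why the step is this small.

Going by these compounds, it remains open whether a longer chain such as butyl, a branched group such as isopropyl, or a chain ending in a hydroxyl group would move the number beyond the scatter. On these data alone, whether methyl at this position would do so on the core of compound 1 also remains open, as compounds 2 and 3 differ from compound 1 in more than one place.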